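Methyl for trifluoromethyl on the aryl of compound 3

The compounds below may be only part of what the source reports. "The series", "measured", "known", "first", "only" and "open" are said of these compounds alone.

Of the compounds shown here, three of the shared core have been read in a functional assay on Huh-7 cells (Homo sapiens) for inhibition, read by sulforhodamine B assay, with a stated time of 72 h; on this read-out higher numbers stand for weaker inhibition and lower numbers for stronger inhibition. Compound 1 `CC(c1ccc(-c2ccccc2)c(F)c1)c1nnc2n1N=C(c1ccc(OC(F)(F)F)cc1)CS2` gives 8400 nM; compound 2 `COc1ccc2cc(C(C)c3nnc4n3N=C(c3ccc(Cl)cc3Cl)CS4)ccc2c1` gives 10700 nM; compound 3 `CC(c1ccc(-c2ccccc2)c(F)c1)c1nnc2n1N=C(c1ccc(C(F)(F)F)cc1)CS2` gives 9400 nM. Compound 3 lies within the scatter of both other compounds: the step of a 1.1-fold higher number from compound 1 to compound 3 (0.05 log units; within the scatter) stays within the scatter, and the gap between compound 3 and compound 2 is of the same small size, so none of the three can be separated from the others.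

Compound 4 `Cc1ccc(C2=Nn3c(nnc3C(C)c3ccc(-c4ccccc4)c(F)c3)SC2)cc1` differs from compound 3 by methyl in place of trifluoromethyl on an aromatic carbon, the aryl going from 4-(trifluoromethyl)phenyl to 4-methylphenyl. For the measured compounds named here, the only measured step that touches this aromatic carbon is a 1.1-fold higher number from compound 1 to compound 3 (0.05 log units; within the scatter), and it stayed within the scatter; no measured pair swaps methyl for trifluoromethyl, so the bearing of that step is indirect. The step is therefore expected to be a 1.0-fold lower number from compound 3 to compound 4 (0.02 log units; within the scatter), with no direction favoured beyond the scatter. Compound 4 is estimated at 9000 nM in this assay, with a range from 3500 nM to 25000 nM.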

Compound 4, half-maximal inhibitory concentration: 7200 nM
Compound 4: middle estimate off by 1.3-fold (0.10 log units), on the high side; measured number inside the range.
By their numbers in this assay, from the lowest: compounds 4, 1, 3 and 2 (each within the scatter of the next).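

On this aromatic carbon of the shared core, methyl now joins trifluoromethyl and trifluoromethoxy, and in this assay the readings stay together: a 1.3-fold lower number from compound 3 to compound 4 (0.12 log units; within the scatter) and a 1.2-fold lower number from compound 1 to compound 4 (0.07 log units; within the scatter) both lie within the scatter. Going from the four heavy atoms of trifluoromethyl to the single heavy atom of methyl therefore gives no separable change at this place, which the earlier pair, with two fluorinated groups only, could not show. Nothing measured here offers an explanation for this flat reading.

As far as these compounds go, whether the flat reading holds for a carboxylic acid or an amine on this aromatic carbon remains open. Also open, from the compounds shown here alone, is whether any change at this position can move the number beyond the scatter.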